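Methyl for Chloro on the Phenol Ring of Compound 3

The compounds below may be only part of what the source reports. "The series", "measured", "known", "first", "only" and "open" are said of these compounds alone.

The set comprises three aryl pyridyl ketones measured for cytotoxicity. In a functional assay on IMR-32 cells (Homo sapiens) for cytotoxicity, read by sulforhodamine B assay, with a stated time of 48 h (on this read-out lower numbers stand for stronger inhibition and higher numbers for weaker inhibition), compound 1 `C=CCOc1cc(Br)ccc1C(=O)c1cccnc1` gives 98000 nM, compound 2 `O=C(c1cccnc1)c1cccc(Cl)c1O` gives 26000 nM, and compound 3 `O=C(c1cccnc1)c1cc(Cl)ccc1O` gives 19500 nM. On these numbers compound 3 stands at the low end: its value sits well apart from that of compound 1, which lies beyond the scatter, while the value of compound 2 is within the scatter of compound 3, so no order between compound 2 and compound 3 can be read from the numbers shown.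

Compound 4 `Cc1ccc(O)c(C(=O)c2cccnc2)c1` has not yet been measured in this assay. It differs from compound 3 in one place: methyl in place of chloro on an aromatic carbon. The two groups have the same heavy-atom count and neither brings or removes a hydrogen-bond donor or acceptor.

Among the measured compounds shown here, no step between two measured compounds mirrors this exchange, so there is no measured step to lean on. Because compound 3 gives 19500 nM in this assay and the change is a single like-for-like swap, the step from compound 3 to compound 4 is expected to be small, at most a modest weakening, and the estimated step is a 1.5-fold higher number from compound 3 to compound 4 (0.19 log units; within the scatter). Compound 4 is expected to give about 30000 nM, within a range from 12000 nM to 75000 nM.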

Compound 4, half-maximal inhibitory concentration: 5540 nM
The estimate for compound 4 lay 5.4-fold (0.73 log units) above the measured number, and the stated range ends above it.
By their numbers in this assay, from the lowest: compound 4; then compounds 3 and 2 (each within the scatter of the next); then compound 1.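

In this assay, the place para to a hydroxy group proves sensitive to the group it carries: methyl in place of chloro gives a 3.5-fold lower number from compound 3 to compound 4 (0.55 log units; beyond the scatter). Among the compounds shown here, the earlier compounds could not show this, as no two of them differ in one place and so they offered no step at all; this is the first single change in the set, and it moves the number by more than the scatter. The swap leaves the heavy-atom count unchanged and neither adds nor removes a hydrogen-bond donor or acceptor, so those counts do not separate the two compounds, and nothing measured here accounts for the lower number of compound 4.

As far as these compounds go, one exchange at one place gives a single step and no trend, so it remains open how an ethyl group, a longer chain, an amine or a carboxylic acid would read at this place. Also open, from the compounds shown here alone, is whether methyl in place of the chloro of compound 2 would give a step of similar size, or whether this step holds only for the place it was read at.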